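This account rests on a few compounds, and the source may have more. Where it says the series, first, only, none or still open, it means among the compounds named here.

Measured compounds:
compound 1, `N#CC1=C(N)N(c2ccc(S(N)(=O)=O)cc2)C2=C(C(=O)CCC2)C1c1ccc(O)cc1`, gives 100% in a functional assay on Ehrlich cells (Mus musculus) for antiproliferative activity, read by trypan blue exclusion, with a stated time of 2 h, tested at 100 ug/mL; a lower number here means a weaker effect, a higher number a stronger effect of the compound at the concentration tested;
compound 2, `COc1ccccc1C1C(C#N)=C(N)N(c2ccc(S(N)(=O)=O)cc2)C2=C1C(=O)CCC2`, gives 0% in this assay;
compound 3, `N#CC1=C(N)N(c2ccc(S(N)(=O)=O)cc2)C2=C(C(=O)CCC2)C1c1cccc([N+](=O)[O-])c1`, gives 71% in this assay.

Compound 3 stands second highest of the three numbers. Its nearest neighbour is compound 1, with a number 29 percentage points lower from compound 1 to compound 3 (beyond the scatter); its furthest is compound 2, with a number 71 percentage points higher from compound 2 to compound 3 (beyond the scatter). The unmeasured compound 4, `COc1ccc(C2C(C#N)=C(N)N(c3ccc(S(N)(=O)=O)cc3)C3=C2C(=O)CCC3)c2ccccc12`, differs from compound 3 by a single change: 4-methoxynaphthalen-1-yl in place of 3-nitrophenyl on a saturated ring carbon.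

All three measured steps touch the same place, the aryl group on the saturated ring carbon, so all bear on this change. Two of them are large: a number 100 percentage points lower from compound 1 to compound 2 (beyond the scatter) and a number 71 percentage points higher from compound 2 to compound 3 (beyond the scatter). One is modest: a number 29 percentage points lower from compound 1 to compound 3 (beyond the scatter). Among the measured compounds shown here, the group that enters, 4-methoxynaphthalen-1-yl, has not been tested at this position, and no measured step shows a methoxy-bearing aryl or a second aromatic ring here other than compound 2, which gave nothing. The swing between compound 2 and compound 3 shows that this position can move the read-out across its whole span, so the estimate is wide. Compound 4 is expected to give 40% in this assay, within a range from 5% to 80%. The expected step is a number 31 percentage points lower from compound 3 to compound 4 (beyond the scatter), a downward step beyond the scatter.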

Compound 4, a percentage reported as activity, at one concentration (the size of the read-out at that concentration, not a potency): 90%
For compound 4 the middle estimate is 50 percentage points below the measured one; the whole stated range lies below it.
By their numbers in this assay, from the lowest: compound 2; then compound 3; then compounds 4 and 1 (each within the scatter of the next).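

The result shows that a methoxy-bearing aryl group at this position does not by itself go with a silent compound in this assay: compound 2 was the only such case so far, yet the data give a number 90 percentage points higher from compound 2 to compound 4 (beyond the scatter) when 4-methoxynaphthalen-1-yl replaces 2-methoxyphenyl. Replacing 3-nitrophenyl with this group gives a number 19 percentage points higher from compound 3 to compound 4 (beyond the scatter) and, with a number 10 percentage points lower from compound 1 to compound 4 (within the scatter) as well, compound 4 cannot be told apart from compound 1, so neither a hydroxyl nor a nitro group is needed on the aryl group for a high read-out at this concentration. No measurement on hand gives a reason for any of these steps.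

The compounds shown leave open whether the methoxy placement or the second aromatic ring separates compound 4 from compound 2, as neither a 4-methoxyphenyl nor a plain naphthalen-1-yl group is among them. They also leave open whether this position tolerates a non-aromatic group such as cyclohexyl, or an aryl group bearing an amine or a carboxylic acid.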